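Swapping a thioether for a piperidinylmethyl group

The compounds below may be only part of what the source reports. "The series", "measured", "known", "first", "only" and "open" are said of these compounds alone.

Measured compounds:
compound 1 `CCOC(=O)C1=C(C)N/C(=C/c2cc(C)n(-c3ccc(OC)cc3)c2C)C1=O`: 3.1 ug/mL
compound 2 `CCOC(=O)C1=C(C)N/C(=C/c2cc(C)n(-c3ccc(SC)cc3)c2C)C1=O`: 3.1 ug/mL

Compound 2 `CCOC(=O)C1=C(C)N/C(=C/c2cc(C)n(-c3ccc(SC)cc3)c2C)C1=O` was tested in a physicochemical assay for solubility, read by nephelometry, measured as kinetic solubility, at pH 2.0 (a lower number here means a less soluble compound, a higher number a more soluble compound), where compound 2 gives 3.1 ug/mL. Its nearest neighbour is compound 1 `CCOC(=O)C1=C(C)N/C(=C/c2cc(C)n(-c3ccc(OC)cc3)c2C)C1=O`, which in this assay gives 3.1 ug/mL; the step of no change at the digits printed from compound 1 to compound 2 (within the scatter) lies within the scatter. Compound 3 `CCOC(=O)C1=C(C)N/C(=C/c2cc(C)n(-c3ccc(CN4CCCCC4)cc3)c2C)C1=O` is not yet measured. It differs from compound 2 by (piperidin-1-yl)methyl in place of methylsulfanyl on an aromatic carbon. Going by the values given here, the only measured step, no change at the digits printed from compound 1 to compound 2 (within the scatter), exchanges one small group for another and does not bear closely on this larger change, so the expectation for compound 3 rests mainly on the value of compound 2 and carries a wide range. For compound 3 the estimated step is a 6.5-fold higher number from compound 2 to compound 3 (0.81 log units; beyond the scatter). Compound 3 is therefore expected to give about 20 ug/mL in this assay, within a range from 2 ug/mL to 200 ug/mL.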

Compound 3, solubility: 50 ug/mL
Estimate against measurement, compound 3: 2.5-fold (0.40 log units) below; measured number inside the range.
By their numbers in this assay, from the lowest: compounds 1 and 2 (each within the scatter of the next); then compound 3.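

In this assay, the position para to a large group on the six-membered aromatic ring proves not to be indifferent to what it carries, although methoxy and methylsulfanyl had stood level there. Placing (piperidin-1-yl)methyl in place of methylsulfanyl gives a 16-fold higher number from compound 2 to compound 3 (1.21 log units; beyond the scatter), and placing it in place of methoxy gives a 16-fold higher number from compound 1 to compound 3 (1.21 log units; beyond the scatter), so the new group stands clear of both smaller groups. No accompanying measurement says what lies behind this rise.

The compounds shown leave open which part of the entering group matters: its ring, its nitrogen or the carbon linking it to the aromatic ring. A morpholin-4-ylmethyl group, an open-chain dimethylaminomethyl group or a carboxylic acid at the same place would help separate these possibilities.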